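A Phenylethynyl Group in Place of Phenylethenyl

A few compounds are considered here, and "the series" means these few. Any claim that something is new, unique, unknown or untested is made for them only; others in the source may bear on it.

Three measured compounds share one core and differ only in the group attached to one aromatic carbon. In an assay on CHO cells for antagonist activity at transient receptor potential cation channel subfamily V member 1 (Homo sapiens), read by FLIPR (a lower number here means a stronger inhibitor, a higher number a weaker inhibitor), compound 1 `CC(C(=O)NCc1ccc(C(F)(F)F)nc1-c1ccco1)c1ccc(NS(C)(=O)=O)c(F)c1` gives 5.8 nM, compound 2 `CC(C(=O)NCc1ccc(C(F)(F)F)nc1-c1ccoc1)c1ccc(NS(C)(=O)=O)c(F)c1` gives 1.4 nM, and compound 3 `CC(C(=O)NCc1ccc(C(F)(F)F)nc1/C=C/c1ccccc1)c1ccc(NS(C)(=O)=O)c(F)c1` gives 2.2 nM. Compound 3 therefore stands second highest of the three numbers: there is a 2.6-fold lower number from compound 1 to compound 3 (0.42 log units; beyond the scatter), while a 1.6-fold higher number from compound 2 to compound 3 (0.20 log units; within the scatter), a gap that stays within the scatter.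

Compound 4 `CC(C(=O)NCc1ccc(C(F)(F)F)nc1C#Cc1ccccc1)c1ccc(NS(C)(=O)=O)c(F)c1` differs from compound 3 in one place: 2-phenylethynyl in place of 2-phenylethenyl on an aromatic carbon. Going by the values given here, no measured step concerns an exchange of this kind, so nothing speaks directly to it. What the measured steps do show is how this aromatic carbon responds to a change of group: a 4.1-fold lower number from compound 1 to compound 2 (0.62 log units; beyond the scatter), a 2.6-fold lower number from compound 1 to compound 3 (0.42 log units; beyond the scatter) and a 1.6-fold higher number from compound 2 to compound 3 (0.20 log units; within the scatter) are all modest, and the three groups tried there have given numbers in this assay that lie within a narrow span. Compound 4 keeps the same count of heavy atoms and the same ring as compound 3, so a step within the scatter is expected, in either direction: a 1.4-fold higher number from compound 3 to compound 4 (0.13 log units; within the scatter). For compound 4 the estimate in this assay is 3 nM, with a range from 1.2 nM to 8 nM.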

Compound 4, inhibition constant: 0.8 nM
For compound 4 the middle estimate is 3.8-fold (0.57 log units) above the measured one; measured number below the stated range.
By their numbers in this assay, from the lowest: compounds 4, 2 and 3 (each within the scatter of the next, the first and the last beyond it); then compound 1.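

At this aromatic carbon, next to the ring nitrogen, this assay separates two groups with the same count of heavy atoms and the same carbon-only aromatic ring: replacing the double bond of 2-phenylethenyl with the triple bond of 2-phenylethynyl gives a 2.8-fold lower number from compound 3 to compound 4 (0.44 log units; beyond the scatter) and so moves the number beyond the scatter, whereas each earlier step exchanged one ring-bearing group for a different ring or linkage. Going by these compounds alone, the same exchange also extends the range seen at this carbon, with a 7.3-fold lower number from compound 1 to compound 4 (0.86 log units; beyond the scatter) as the largest step so far, while a 1.8-fold lower number from compound 2 to compound 4 (0.24 log units; within the scatter) leaves 2-phenylethynyl and furan-3-yl unranked, since that step stays within the scatter. Nothing shown here accounts for the difference between the triple and double bonds.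

The compounds shown leave open how a saturated 2-phenylethyl chain would compare with the 2-phenylethynyl and 2-phenylethenyl groups, and whether the triple bond needs its phenyl ring at all. They also do not show what a methoxy group on that phenyl ring, or an amine placed directly on this aromatic carbon, would do in this assay to the number.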